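The source may report more compounds than this note shows. Statements on the series, on what has been measured and on what is new or still open speak of the compounds shown alone.

Compound 1 `Cc1nc(-c2ccccc2)c(C(=O)N2CCN(c3ccccc3Cl)CC2)o1` is the reference point of this small set. In a functional assay on HL-60 cells (Homo sapiens) for inhibition, read by MTT assay, with a stated time of 72 h (a lower number here means a stronger inhibitor, a higher number a weaker inhibitor), compound 1 gives 124 nM, the lower of the two numbers in hand, though the gap to compound 2 is within the scatter. Compound 2 `COc1cc(OC)cc(N2CCN(C(=O)c3onc(C)c3-c3cccc(F)c3)CC2)c1` gives 152 nM in this assay, so neither is called the stronger. Compound 3 `Cc1nc(-c2cccc(OP(=O)(O)O)c2)c(C(=O)N2CCN(c3cccc(Cl)c3)CC2)o1` returns > 1000 nM, which is the limit of > 1000 nM in this assay, at which 1 of the 3 values shown sits, rather than a number.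

Compound 4 `COc1cccc(N2CCN(C(=O)c3oc(C)nc3-c3ccccc3)CC2)c1` has not yet been measured. It departs from compound 1 at one place: 3-methoxyphenyl in place of 2-chlorophenyl on an amine nitrogen in a ring. Among the measured compounds shown here, no measured pair differs in exactly this way, so the size of the step is open. Compound 2, which carries a different group on that amine nitrogen, lands close to compound 1, and that argues for a modest step rather than a large one. The expectation for the step from compound 1 to compound 4 is a 1.6-fold higher number from compound 1 to compound 4 (0.21 log units; within the scatter), a slight weakening at most and possibly none beyond the scatter. Compound 4 is accordingly estimated at 200 nM, with a range from 80 nM to 600 nM.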

Compound 4, half-maximal inhibitory concentration: 34.8 nM
Compound 4: middle estimate off by 5.7-fold (0.76 log units), on the high side, and the stated range ends above it.
By their numbers in this assay, from the lowest: compound 4; then compounds 1 and 2 (each within the scatter of the next). At a limit, above all of these: compound 3.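

Among the compounds shown here, the aryl group on the amine nitrogen is not a silent position on the core of compound 1: exchanging 2-chlorophenyl for 3-methoxyphenyl gives a 3.6-fold lower number from compound 1 to compound 4 (0.55 log units; beyond the scatter) in this assay, the only single-place step so far. The exchange replaces a whole group, with 2-chlorophenyl carrying no hydrogen-bond acceptor and 3-methoxyphenyl carrying one, so the substituent and its place on the phenyl ring change together. Nothing measured here gives a reason for the step.

Still open, on these data alone, is whether the lower number follows the methoxy group or its place, which 2-methoxyphenyl or 3-chlorophenyl on this same core would separate. Also open, as far as these compounds go, is whether a larger ether such as ethoxy, or a carboxylic acid, in place of the methoxy group would keep the number of compound 4.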